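A bromo step on a shared core, carried to a second compound

The compounds below may be only part of what the source reports. "The series", "measured", "known", "first", "only" and "open" are said of these compounds alone.

All four compounds share one core, shown as compound 1, `O=C1N=C(N2N=C(c3ccccc3)CC2c2ccccc2O)S/C1=C1/C(=O)Nc2ccccc21`. Tested in a functional assay on cells (Cancer cell lines, Homo sapiens) for cytotoxicity, read by sulforhodamine B assay, with a stated time of 48 h (a higher number here means a weaker inhibitor of growth, a lower number a stronger inhibitor of growth), compound 1 gives 1990 nM. Compound 2, `O=C1N=C(N2N=C(c3ccccc3)CC2c2ccccc2O)S/C1=C1/C(=O)Nc2ccc(Br)cc21`, differs from compound 1 by bromo in place of hydrogen on an aromatic carbon and in this assay compound 2 gives 210 nM, so the step is a 9.5-fold lower number from compound 1 to compound 2 (0.98 log units; beyond the scatter). Compound 3, `CN(C)c1ccc(C2CC(c3ccccc3)=NN2C2=NC(=O)/C(=C3\C(=O)Nc4ccccc43)S2)cc1`, differs from compound 1 by 4-(dimethylamino)phenyl in place of 2-hydroxyphenyl on a saturated ring carbon; in this assay compound 3 gives 2550 nM, and the step of a 1.3-fold higher number from compound 1 to compound 3 (0.11 log units; within the scatter) shows that the two cores behave alike within the usual scatter. Compound 3 holds the highest of the three numbers, but its gap to compound 1 is within the scatter, so no order between those two can be claimed.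

Compound 4, `CN(C)c1ccc(C2CC(c3ccccc3)=NN2C2=NC(=O)/C(=C3\C(=O)Nc4ccc(Br)cc43)S2)cc1`, has not yet been measured. It differs from compound 3 by bromo in place of hydrogen on an aromatic carbon, and the place of this change is described in the same words as for the change from compound 1 to compound 2, so it is the same change carried onto the core of compound 3. Within the data shown here, the only measured example of this change is the step of a 9.5-fold lower number from compound 1 to compound 2 (0.98 log units; beyond the scatter), and the expectation for compound 4 rests on it alone, with a wider range to allow that one example may not transfer fully. The expected step is an 8.5-fold lower number from compound 3 to compound 4 (0.93 log units; beyond the scatter). Compound 4 is therefore estimated to give 300 nM in this assay, with a range from 120 nM to 900 nM.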

Compound 4, concentration for 50% growth inhibition: 200 nM
Beside the measured number, compound 4's estimate is 1.5-fold (0.18 log units) above it; the measured number falls inside the stated range.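

In this assay, bromo in place of hydrogen on an aromatic carbon gives a 13-fold lower number from compound 3 to compound 4 (1.11 log units; beyond the scatter), and this step agrees with the earlier one on the other core: the same change on two cores in this assay, a 9.5-fold lower number (0.98 log units; beyond the scatter) from compound 1 to compound 2 and a 13-fold lower number (1.11 log units; beyond the scatter) from compound 3 to compound 4, 1.3-fold (0.13 log units) apart, within the scatter of two such steps. With the bromo present, 4-(dimethylamino)phenyl in place of 2-hydroxyphenyl on a saturated ring carbon gives a 1.1-fold lower number from compound 2 to compound 4 (0.02 log units; within the scatter), and this agrees with the same swap without the bromo: the same change on two cores in this assay, a 1.3-fold higher number (0.11 log units; within the scatter) from compound 1 to compound 3 and a 1.1-fold lower number (0.02 log units; within the scatter) from compound 2 to compound 4, 1.3-fold (0.13 log units) apart, within the scatter of two such steps. Across these four compounds, then, the bromo step carries from one core to the other with its size intact and the two changes show no sign of depending on each other, but this rests on a single pair of cores in a single assay and does not show that the step would carry to any other core, nor does it say why the bromo has this effect.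

The compounds shown leave open whether the step belongs to bromo itself or would also appear with chloro, fluoro or methyl on that same aromatic carbon, and whether it would hold on another carbon of that ring. They also leave open whether it would persist with a different group on the saturated ring carbon, such as an unsubstituted phenyl or a 4-methoxyphenyl.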